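Bromine and the Indolinone Core in a Cytotoxicity Series

The source may report more compounds than this note shows. Statements on the series, on what has been measured and on what is new or still open speak of the compounds shown alone.

Four compounds share one core and differ in two places. Compound 1 `COc1ccc(C2CC(c3ccccc3)=NN2C2=NC(=O)/C(=C3\C(=O)Nc4ccccc43)S2)cc1` carries a methoxy group, compound 2 `COc1ccc(C2CC(c3ccccc3)=NN2C2=NC(=O)/C(=C3\C(=O)Nc4ccc(Br)cc43)S2)cc1` adds a bromine to the fused ring, compound 3 `CN(C)c1ccc(C2CC(c3ccccc3)=NN2C2=NC(=O)/C(=C3\C(=O)Nc4ccccc43)S2)cc1` has the core of compound 1 with dimethylamino in place of methoxy on an aromatic carbon, and compound 4 `CN(C)c1ccc(C2CC(c3ccccc3)=NN2C2=NC(=O)/C(=C3\C(=O)Nc4ccc(Br)cc43)S2)cc1` combines both changes.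

In a functional assay on cells (Cancer cell lines, Homo sapiens) for cytotoxicity, read by sulforhodamine B assay, with a stated time of 48 h (on this read-out higher numbers stand for weaker inhibition of growth and lower numbers for stronger inhibition of growth), compound 1 gives 2380 nM. Compound 2 gives 200 nM, so a 12-fold lower number from compound 1 to compound 2 (1.08 log units; beyond the scatter), where the change is bromo in place of hydrogen on an aromatic carbon. Compound 3 gives 7420 nM, and a 3.1-fold higher number from compound 1 to compound 3 (0.49 log units; beyond the scatter).

The change from compound 3 to compound 4 is bromo in place of hydrogen on an aromatic carbon, the same change as from compound 1 to compound 2, made on a core that differs as described above. Among the compounds with values here, the step is expected to be a 9.3-fold lower number from compound 3 to compound 4 (0.97 log units; beyond the scatter), somewhat less than the earlier one, because only a single pair, a 12-fold lower number from compound 1 to compound 2 (1.08 log units; beyond the scatter), shows how this bromine acts, and the core of compound 3 is the weaker one. Compound 4 is therefore expected to give about 800 nM, with a plausible range from 300 nM to 2500 nM.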

Compound 4, concentration for 50% growth inhibition: 220 nM
For compound 4 the middle estimate is 3.6-fold (0.56 log units) above the measured one; the whole stated range lies above it.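

Adding the bromine lowers the number on both cores in this assay, but the size of the drop does not carry over unchanged, with a 34-fold lower number from compound 3 to compound 4 (1.53 log units; beyond the scatter) on the core of compound 3: the same change on two cores in this assay, a 12-fold lower number (1.08 log units; beyond the scatter) from compound 1 to compound 2 and a 34-fold lower number (1.53 log units; beyond the scatter) from compound 3 to compound 4, 2.8-fold (0.45 log units) apart, beyond the scatter of two such steps. Swapping methoxy for dimethylamino carries over even less well, since with the bromine present the swap gives a 1.1-fold higher number from compound 2 to compound 4 (0.04 log units; within the scatter), and the gap seen without bromine no longer appears: the same change on two cores in this assay, a 3.1-fold higher number (0.49 log units; beyond the scatter) from compound 1 to compound 3 and a 1.1-fold higher number (0.04 log units; within the scatter) from compound 2 to compound 4, 2.8-fold (0.45 log units) apart, beyond the scatter of two such steps. So in these four compounds the two changes do not simply add up, and the effect of one depends on whether the other is present, yet this rests on a single pair of steps for each change and does not show why they interact or whether the same holds on any other core.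

The compounds shown leave open whether a chloro or fluoro group in the place of the bromine would act the same way. They also leave open whether the bromine would have a similar effect with a hydroxy group or a longer alkoxy chain in place of methoxy.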